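Working notes: from compound 3 to compound 4

The source may report more compounds than this note shows. Statements on the series, on what has been measured and on what is new or still open speak of the compounds shown alone.

In a functional assay on MDA-MB-231 cells (Homo sapiens), read by microscopy and transwell migration, with a stated time of 24 h (a lower number here means a stronger inhibitor, a higher number a weaker inhibitor), compound 1 `CCCCCCCCCCCCn1c(-c2ccc(C)cc2C)cs/c1=N\C(=O)c1ccccc1` gives 24 nM and compound 3 `Cn1c(-c2ccccc2Cl)cs/c1=N\C(=O)c1ccccc1` gives 268 nM while compound 2 `COc1cc(-c2csc(NC(=O)c3cccc(OC)c3OC)n2)cc(OC)c1OC` gives 15000 nM as the highest number of the three. Compound 3 therefore stands second highest, and its gaps to both other compounds lie beyond the scatter.

Within the data shown here, the next compound is compound 4 `Cn1c(-c2ccc(Br)cc2)cs/c1=N\C(=O)c1ccccc1` with 4-bromophenyl in place of 2-chlorophenyl on an aromatic carbon as the only change. That carbon sits next to the ring nitrogen and next to the ring atom that bears a methyl group. Among the measured compounds shown here, no measured pair isolates this swap, so the expectation stays anchored on compound 3 at 268 nM with a wide margin. The expected step is a 1.3-fold higher number from compound 3 to compound 4 (0.12 log units; within the scatter) in the direction of a slightly higher number, and none beyond the scatter is expected. In this assay the estimate for compound 4 is 350 nM with an expected range from 100 nM to 1300 nM on measurement.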

Compound 4, half-maximal inhibitory concentration: 125 nM
Compound 4: the middle estimate sits 2.8-fold (0.45 log units) above what was measured; the measured number falls inside the stated range.
By their numbers in this assay, from the lowest: compound 1; then compound 4; then compound 3; then compound 2.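

In this assay, among these compounds, 4-bromophenyl in place of 2-chlorophenyl on the aromatic carbon next to the ring nitrogen gives a 2.1-fold lower number from compound 3 to compound 4 (0.33 log units; beyond the scatter), a modest change and the first step that differs in one place. This position therefore responds to a change of aryl group, even though both groups have 7 heavy atoms, 0 hydrogen-bond donors and 0 hydrogen-bond acceptors. No available measurement accounts for the step.

The step exchanges chlorine for bromine and moves the halogen on the phenyl ring at once, and the compounds shown do not separate these two changes. Also open, on these data alone, is how a phenyl group bearing a morpholine or a carboxylic acid would read at this position in this assay.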